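Aminoquinoline ethers: methoxy to trifluoromethoxy on the benzamide

A few compounds are considered here, and "the series" means these few. Any claim that something is new, unique, unknown or untested is made for them only; others in the source may bear on it.

Measured compounds:
- compound 1, `CC(CNCC1CC1)Oc1cccc2ccc(N)nc12`: 460 nM
- compound 2, `CC(CNc1ccc2[nH]ncc2c1)Oc1cccc2ccc(N)nc12`: 8180 nM
- compound 3, `COc1cccc(C(=O)NCCCOc2cccc3ccc(N)nc23)c1`: 30 nM

Three compounds share the aminoquinoline ether core and have been run in a functional assay on IMR-32 cells with melanin-concentrating hormone receptor 1 (Homo sapiens) as the target, read by fluorescence; on this read-out lower numbers stand for stronger inhibition and higher numbers for weaker inhibition. Compound 3 gives the lowest number of the three in this assay; compound 1 lies at a higher number beyond the scatter, and compound 2 is higher still, also well beyond the scatter. Among the compounds with values here, compounds 1 and 2 carry amine-linked side chains, whereas compound 3 carries a benzamide with a methoxy group, so no single-point steps connect the three.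

The next compound, compound 4, `Nc1ccc2cccc(OCCCNC(=O)c3cccc(OC(F)(F)F)c3)c2n1`, is a single-point variation on compound 3: trifluoromethyl in place of methyl on an oxygen on an aromatic ring. Everything else, the propyl ether linker, the amide and the aromatic amine, is unchanged. Within the data shown here, no measured pair in the set shows what this kind of exchange does in this assay, so the expectation rests only on the standing of compound 3 and the small size of the change. A step of no more than the usual scatter, in either direction, is expected.

Compound 4 is therefore expected near 30 nM, within the range 10 nM to 90 nM. The estimated step is no change at the digits printed from compound 3 to compound 4 (within the scatter).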

Compound 4, half-maximal inhibitory concentration: 20 nM
For compound 4 the middle estimate is 1.5-fold (0.18 log units) above the measured one; the range from low to high includes it.
By their numbers in this assay, from the lowest: compounds 4 and 3 (each within the scatter of the next); then compound 1; then compound 2.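

In this assay, within the data shown here, trifluoromethyl in place of methyl on an oxygen on an aromatic ring gives a 1.5-fold lower number from compound 3 to compound 4 (0.18 log units; within the scatter) and provides the first single-point step. The exchange brings in 4 heavy atoms where 1 stood, yet compound 3 at 30 nM and compound 4 at 20 nM cannot be told apart. This place on the benzamide therefore accepts the larger group without a step beyond the scatter, although this single pair speaks only for this one exchange. No supporting data bear on why the two values stay so close.

As far as these compounds go, it remains open whether the same place would hold its number with an ethyl group or a longer chain on the oxygen, or with a carboxylic acid or an amine in place of the whole methoxy group. From the compounds shown here alone, it also remains open whether methoxy to trifluoromethoxy would give a similarly small step on a different side chain or in a compound with a much higher number in this read-out.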